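The source may report more compounds than this note shows. Statements on the series, on what has been measured and on what is new or still open speak of the compounds shown alone.

Measured compounds:
Compound 1 `Cc1ccccc1Nc1nc(NCc2ccco2)ncc1Cl`: in a functional assay on Jurkat cells (Homo sapiens) for inhibition, read by CCK-8 assay, with a stated time of 48 h (on this read-out higher numbers stand for weaker inhibition of growth and lower numbers for stronger inhibition of growth), compound 1 gives > 100000 nM, which is a limit of the assay rather than a number.
Compound 2 `COc1ccc(CNc2nc(Nc3ccc(N4CCN(C)CC4)cn3)ncc2Cl)cc1`: in this assay compound 2 gives 12900 nM.

Among the compounds with values here, compound 2 therefore holds the only numerical value in this set. Compound 1 sits at a limit (the limit of > 100000 nM in this assay, at which 1 of the 2 values shown sits). Compound 3 `COc1ccc(Nc2nc(Nc3ccc(N4CCN(C)CC4)cn3)ncc2Cl)cc1` differs from compound 2 by 4-methoxyphenyl in place of 4-methoxybenzyl on a nitrogen on an aromatic ring. Within the data shown here, no measured pair shows this change, so its size cannot be read from the data. A modest gain in growth inhibition, close to the scatter, is expected a 2.2-fold lower number from compound 2 to compound 3 (0.33 log units; beyond the scatter). Compound 3 is estimated at 6000 nM, expected to lie between 1500 nM and 25000 nM.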

Compound 3, concentration for 50% growth inhibition: 11200 nM
Estimate against measurement, compound 3: 1.9-fold (0.27 log units) below; the range from low to high includes it.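

In this assay, putting 4-methoxyphenyl in place of 4-methoxybenzyl on this nitrogen gives a 1.2-fold lower number from compound 2 to compound 3 (0.06 log units; within the scatter). Within the data shown here, this is the first direct reading at this position, and it shows that the two groups cannot be told apart here. No measurement shown offers a reason for this result.

As far as these compounds go, it remains open whether a different kind of group on this nitrogen, such as a carboxylic acid or a longer chain ending in an amine, would move the number beyond the scatter.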